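Swapping fluoro for trifluoromethyl on the most active compound

The source may report more compounds than this note shows. Statements on the series, on what has been measured and on what is new or still open speak of the compounds shown alone.

The measured compounds differ only in one halogen: compound 1 (`COc1cc(C(=O)c2sc(-c3ccc(Cl)cc3)cc2N)cc(OC)c1OC`) with chloro, compound 2 (`COc1cc(C(=O)c2sc(-c3ccc(I)cc3)cc2N)cc(OC)c1OC`) with iodo, and compound 3 (`COc1cc(C(=O)c2sc(-c3ccc(F)cc3)cc2N)cc(OC)c1OC`) with fluoro. In a functional assay on L1210 cells (Mus musculus) for antiproliferative activity (a lower number here means a stronger inhibitor, a higher number a weaker inhibitor), compound 3 gives the lowest number of the three at 20 nM while compound 1 gives 93 nM and compound 2 gives 400 nM on the same scale. Compound 4 (`COc1cc(C(=O)c2sc(-c3ccc(C(F)(F)F)cc3)cc2N)cc(OC)c1OC`) carries trifluoromethyl in place of fluoro on an aromatic carbon. For the measured compounds named here, two measured steps bear on this, both halogen swaps at that carbon: one modest (a 4.7-fold lower number from compound 1 to compound 3 (0.67 log units; beyond the scatter)) and one large (a 20-fold lower number from compound 2 to compound 3 (1.30 log units; beyond the scatter)). Fluoro gave the lower number in both, but no measured compound carries trifluoromethyl. A modest rise in this assay is therefore expected (a 6.0-fold higher number from compound 3 to compound 4 (0.78 log units; beyond the scatter)). Compound 4 is estimated at 120 nM (range 30 nM to 500 nM).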

Compound 4, half-maximal inhibitory concentration: 370 nM
For compound 4 the middle estimate is 3.1-fold (0.49 log units) below the measured one; low and high end bracket the measured number.
By their numbers in this assay, from the lowest: compound 3; then compound 1; then compounds 4 and 2 (each within the scatter of the next).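

In this assay the step of a 19-fold higher number from compound 3 to compound 4 (1.27 log units; beyond the scatter) is large, so trifluoromethyl at this carbon does not keep the low number that fluoro gave. The step of a 1.1-fold lower number from compound 2 to compound 4 (0.03 log units; within the scatter) puts the new group level with iodo, and the step of a 4.0-fold higher number from compound 1 to compound 4 (0.60 log units; beyond the scatter) puts it on the weaker side of chloro, leaving fluoro alone at the low end among these four compounds. No measurement shown gives a reason for this.

Going by these compounds, whether a methoxy group, a nitrile or an amine at this carbon would give a number as low as that of compound 3 stays open.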